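The source may report more compounds than this note shows. Statements on the series, on what has been measured and on what is new or still open speak of the compounds shown alone.

In a functional assay on Gurav cells (Homo sapiens) for inhibition, read by sulforhodamine B assay (a lower number here means a stronger inhibitor of growth, a higher number a weaker inhibitor of growth), compound 3 (`Oc1cccc2[nH]c(-c3ccc(-c4ccc(-c5cccc(Cl)c5)cc4)cc3)nc12`) gives 2310 nM and compound 2 (`Oc1cccc2[nH]c(-c3ccc(-c4ccc(-c5ccc(F)cc5)cc4)cc3)nc12`) gives 2860 nM, a pair separated by a 1.2-fold lower number from compound 2 to compound 3 (0.09 log units; within the scatter). Compound 1 (`COc1ccc(-c2ccc(-c3ccc(-c4nc5ccccc5[nH]4)cc3)cc2)cc1OC`) stands higher at 9230 nM. Compound 4 (`COc1ccc(-c2ccc(-c3ccc(-c4nc5c(O)cccc5[nH]4)cc3)cc2)cc1OC`) brings 3,4-dimethoxyphenyl in place of 3-chlorophenyl, on an aromatic carbon para to a large group: 3,4-dimethoxyphenyl in place of 3-chlorophenyl on an aromatic carbon. Going by the values given here, the one measured swap of this terminal group, a 1.2-fold lower number from compound 2 to compound 3 (0.09 log units; within the scatter), is small. Without the hydroxy group of compound 4 but with the same 3,4-dimethoxyphenyl group, compound 1 gives 9230 nM, so some upward drift is expected. The expected change is a 1.5-fold higher number from compound 3 to compound 4 (0.18 log units; within the scatter), toward a slightly higher number and not clearly beyond the scatter. For compound 4 the estimated value is 3500 nM, expected between 1400 nM and 8500 nM.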

Compound 4, concentration for 50% growth inhibition: 1110 nM
Compound 4: the middle estimate sits 3.2-fold (0.50 log units) above what was measured; the whole stated range lies above it.
By their numbers in this assay, from the lowest: compound 4; then compounds 3 and 2 (each within the scatter of the next); then compound 1.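

In this assay, 3,4-dimethoxyphenyl at this terminal position moves the number beyond the scatter, a 2.1-fold lower number from compound 3 to compound 4 (0.32 log units; beyond the scatter) and a 2.6-fold lower number from compound 2 to compound 4 (0.41 log units; beyond the scatter), whereas the swap between 4-fluorophenyl and 3-chlorophenyl stayed within it. With 3,4-dimethoxyphenyl held fixed, the hydroxy group gets its first direct reading: an 8.3-fold lower number from compound 1 to compound 4 (0.92 log units; beyond the scatter). No measurement in hand accounts for either change.

On these data alone, whether a single methoxy group would suffice remains open, as does the effect of an amine or a carboxylic acid on this ring. Also open, as far as these compounds go, is whether the hydroxy step holds with 3-chlorophenyl or 4-fluorophenyl as the terminal group.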